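A chloro exchange among compounds held at a limit

A few compounds are considered here, and "the series" means these few. Any claim that something is new, unique, unknown or untested is made for them only; others in the source may bear on it.

Measured in an ADME assay on HepG2 cells (Homo sapiens) for cytotoxicity, read by luminescence, with a stated time of 72 h; on this read-out lower numbers stand for an effect already at smaller amounts and higher numbers for an effect only at larger amounts of compound:
Compound 1 `CCOC(=O)c1c(-c2cccc(OCC(C)C)c2)[nH]c2cc(OC)ccc2c1=O`: > 21500 nM
Compound 2 `CCOC(=O)c1c(-c2cccc(C(F)(F)F)c2)[nH]c2cc(OC)ccc2c1=O`: > 21500 nM

Neither entry is a true number. Compound 2 stands only at a limit of > 21500 nM. The data so far consist of the limit of > 21500 nM in this assay, at which 2 of the 2 values shown sit.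

Compound 3 `CCOC(=O)c1c(-c2cccc(Cl)c2)[nH]c2cc(OC)ccc2c1=O` keeps the shared core of compound 2 and changes one group: chloro in place of trifluoromethyl on an aromatic carbon. In short, chloro replaces trifluoromethyl on an aromatic carbon.

Going by the values given here, one measured step bears on this exchange, since it also changes a group on an aromatic carbon: a step that the two limits leave unreadable from compound 1 to compound 2. It offers no size to carry over, yet both compounds remain at the limit. In this assay the expected change, a step that the limit leaves unreadable from compound 2 to compound 3, is therefore none beyond the scatter, and a further limit is the likeliest report.

The estimate for compound 3 is 30000 nM, with an expected range from 15000 nM to 60000 nM.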

Compound 3, half-maximal effective concentration: > 21500 nM
Compound 3 gave a limit, no number; the forecaster's own chance of this, stated with the estimate: 80%; the middle value does not contradict the limit.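

Going by these compounds alone, compound 1, compound 2 and compound 3 are all reported only as limits, not numbers, so no step among them can be read. The compounds shown leave open what true value each would give in this assay, and so whether isobutoxy, trifluoromethyl and chloro differ here at all.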